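The source may report more compounds than this note shows. Statements on the series, on what has been measured and on what is new or still open speak of the compounds shown alone.

Compound 3 `Nc1nc(O)c2c(n1)n(C1OC(CO)[C@@H](O)[C@H]1O)c(=O)n2Cc1ccccc1` stands lowest in a functional assay (B cells) with Mus musculus as the target (a lower number here means that less compound is needed, a higher number that more compound is needed for the effect), among the three measured compounds, at 6 uM. Compound 2 `Nc1nc(O)c2c(n1)n(C1OC(CO)[C@@H](O)[C@H]1O)c(=O)n2Cc1ccc([N+](=O)[O-])cc1` gives 40 uM in this assay, and compound 1 `COc1ccc(Cn2c(=O)n(C3OC(CO)[C@@H](O)[C@H]3O)c3nc(N)nc(O)c32)cc1` gives 135 uM. Compound 4 `Nc1nc(O)c2c(n1)n(C1OC(CO)[C@@H](O)[C@H]1O)c(=O)n2Cc1ccc(OCc2ccccc2)cc1` differs from compound 3 by benzyloxy in place of hydrogen on an aromatic carbon. Among the compounds with values here, the steps that bear on this are a 23-fold lower number from compound 1 to compound 3 (1.35 log units; beyond the scatter) and a 6.7-fold lower number from compound 2 to compound 3 (0.82 log units; beyond the scatter), both showing that the bare ring gave the lowest number, while the step of a 3.4-fold lower number from compound 1 to compound 2 (0.53 log units; beyond the scatter) shows that the size of the change depends on which group sits there. A larger benzyloxy group is therefore expected to raise the number for compound 4, a step of about a 6.7-fold higher number from compound 3 to compound 4 (0.82 log units; beyond the scatter). Compound 4 is thus estimated at 40 uM, within 10 uM to 150 uM.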

Compound 4, concentration for half-maximal effect: 8 uM
For compound 4 the middle estimate is 5.0-fold (0.70 log units) above the measured one, outside the stated range (below it).
By their numbers in this assay, from the lowest: compounds 3 and 4 (each within the scatter of the next); then compound 2; then compound 1.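

In this assay the number barely moves with benzyloxy on this aromatic carbon, a 1.3-fold higher number from compound 3 to compound 4 (0.12 log units; within the scatter), so a large group here need not raise the number, although methoxy and nitro both did. The added phenyl sets the two oxygen-linked groups far apart, a 17-fold lower number from compound 1 to compound 4 (1.23 log units; beyond the scatter), a step that turns the poorest group shown into one level with the bare ring. Benzyloxy also separates clearly from nitro, a 5.0-fold lower number from compound 2 to compound 4 (0.70 log units; beyond the scatter), at this same place. From the compounds shown here alone, how an amine, a carboxylic acid or a longer chain would behave here remains open. Nothing shown explains why these groups differ.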